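The source may hold more compounds than are shown below. What is called first, only, known or untested is meant among the compounds shown, and "the series" means these compounds.

Compound 1 `c1csc(C2=NNC(c3ccc(N4CCCCC4)cc3)C2)c1`: 20800 nM in an ADME assay on PBMC cells (Homo sapiens) for cytotoxicity, with a stated time of 5 days; a higher number here means a weaker inhibitor, a lower number a stronger inhibitor. Compound 2 `c1cc(C2=NNC(c3ccc(N4CCCCC4)cc3)C2)cs1`: > 100000 nM, which is a limit of this assay rather than a number. Compound 3 `Cc1cc(C2=NNC(c3ccc(N4CCCCC4)cc3)C2)c(C)s1`: 77500 nM.

Of the two numbers shown, compound 3 holds the higher one; its nearest neighbour is compound 1, and the step of a 3.7-fold higher number from compound 1 to compound 3 (0.57 log units; beyond the scatter) lies beyond the scatter. Compound 4 `Ic1ccc(C2=NNC(c3ccc(N4CCCCC4)cc3)C2)s1` differs from compound 3 by 5-iodothiophen-2-yl in place of 2,5-dimethylthiophen-3-yl on a carbon with a double bond to nitrogen. Among the measured compounds shown here, two measured steps bear on this change: a 3.7-fold higher number from compound 1 to compound 3 (0.57 log units; beyond the scatter) and an at least 1.2-fold lower number from compound 2 to compound 3 (0.11 log units; that floor lies within the scatter), the second within the scatter. Compound 1, carrying thiophen-2-yl, gave the lower number in this assay, so a modest fall is expected; the expected step is a 2.6-fold lower number from compound 3 to compound 4 (0.41 log units; beyond the scatter). Compound 4 is thus estimated at 30000 nM, within 10000 nM to 90000 nM.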

Compound 4, half-maximal inhibitory concentration: > 100000 nM
Compound 4 was reported as a limit; the forecaster's own chance of this, stated with the estimate: 15%; middle value at least 3.3-fold (0.52 log units) away from the limit.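

The iodo in place of hydrogen gives an at least 4.8-fold higher number from compound 1 to compound 4 (0.68 log units; beyond the scatter), so keeping the thiophen-2-yl attachment does not by itself hold the number near that of compound 1, and a single atom added to that ring is enough to move it. The result for compound 4 is a limit of the assay, and against compound 3 it gives an at least 1.2-fold higher number from compound 3 to compound 4 (0.11 log units; that floor lies within the scatter), which does not separate the two groups. The step between compound 2 and compound 4 cannot be read: the limit of > 100000 nM in this assay, at which 2 of the 4 values shown sit.

Going by these compounds, what a methyl or a chlorine in place of the iodo would give in this assay stays open.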